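Swapping the sulfonyl aryl of compound 3 for an isoquinoline

This account rests on a few compounds, and the source may have more. Where it says the series, first, only, none or still open, it means among the compounds named here.

Of the compounds shown here, three sharing one core have been measured in a functional assay for inhibition of B1 bradykinin receptor (Homo sapiens), read by calcium flux; on this read-out lower numbers stand for stronger inhibition and higher numbers for weaker inhibition. Compound 1 `CCCCOc1ccc(S(=O)(=O)N2CCCC[C@H]2CC(=O)N[C@@H]2CCCc3cc(CNC(C)(C)C)ccc32)cc1` gives 590 nM, compound 2 `CC(C)(C)NCc1ccc2c(c1)CCC[C@H]2NC(=O)C[C@@H]1CCCCN1S(=O)(=O)c1ccc(Cl)cc1` gives 810 nM, and compound 3 `CC(C)(C)NCc1ccc2c(c1)CCC[C@H]2NC(=O)C[C@@H]1CCCCN1S(=O)(=O)c1cccc(Cl)c1` gives 73 nM, the lowest of the three numbers. The step of a 1.4-fold higher number from compound 1 to compound 2 (0.14 log units; within the scatter) shows that exchanging the group on the aromatic carbon barely moved the read-out, whereas an 8.1-fold lower number from compound 1 to compound 3 (0.91 log units; beyond the scatter) and an 11-fold lower number from compound 2 to compound 3 (1.05 log units; beyond the scatter) show that the aryl on the sulfonyl sulfur can shift the number well beyond the scatter.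

Compound 4 `CC(C)(C)NCc1ccc2c(c1)CCC[C@H]2NC(=O)C[C@@H]1CCCCN1S(=O)(=O)c1cccc2cnccc12` differs from compound 3 in one place: isoquinolin-5-yl in place of 3-chlorophenyl on a sulfonyl sulfur. Within the data shown here, no measured step involves a bicyclic aryl on the sulfonyl sulfur, so there is no direct parallel, only the sign that this position is sensitive. Because an 11-fold lower number from compound 2 to compound 3 (1.05 log units; beyond the scatter) shows that leaving the 3-chlorophenyl pattern can cost a large amount, compound 4 is expected to give a higher number than compound 3, with the step of a 2.7-fold higher number from compound 3 to compound 4 (0.44 log units; beyond the scatter) taken as a modest loss. The estimate for compound 4 is 200 nM, within a range from 40 nM to 1000 nM.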

Compound 4, half-maximal inhibitory concentration: 4300 nM
Compound 4: middle estimate off by 22-fold (1.33 log units), on the low side; the measured number lies above the stated range.
By their numbers in this assay, from the lowest: compound 3; then compounds 1 and 2 (each within the scatter of the next); then compound 4.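

In this assay, compound 4 is the weakest of the four, and the isoquinolin-5-yl group costs activity against every phenyl group measured on the sulfonyl sulfur: a 59-fold higher number from compound 3 to compound 4 (1.77 log units; beyond the scatter), a 5.3-fold higher number from compound 2 to compound 4 (0.72 log units; beyond the scatter) and a 7.3-fold higher number from compound 1 to compound 4 (0.86 log units; beyond the scatter). The earlier compounds shown here showed this position responding only to changes among substituted phenyl groups, whereas this result shows that it also tolerates poorly a two-ring aryl containing a ring nitrogen, even when compared with the less active 4-butoxyphenyl and 4-chlorophenyl compounds. Nothing measured here accounts for the loss.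

The compounds shown cannot separate the effect of the second ring from that of the ring nitrogen, a question that a naphthalen-1-yl group on the sulfonyl sulfur could address. From the compounds shown here alone, it also remains open whether an isoquinoline attached through a different ring carbon would give a similar number.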